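Sulfone series: clearance notes toward compound 4

The source may report more compounds than this note shows. Statements on the series, on what has been measured and on what is new or still open speak of the compounds shown alone.

Measured compounds:
compound 1 `O=S(=O)(c1ccc(F)cc1)c1cnc2cc(Cl)c(F)cc2c1-c1ccc(Cl)cc1`, 0.57 mL/min
compound 2 `O=S(=O)(c1ccc(F)c(Cl)c1)c1cnc2cc(F)ccc2c1-c1ccc(Cl)cc1`, 0.45 mL/min
compound 3 `O=S(=O)(c1ccc(F)cc1)c1cnc2cc(F)c(Cl)cc2c1-c1ccc(Cl)cc1`, 0.34 mL/min

In an ADME assay on microsomes from liver (Rattus norvegicus) for metabolic stability, tested at 2.5 uM (on this read-out lower numbers stand for slow clearance and higher numbers for fast clearance), compound 1 gives 0.57 mL/min, compound 2 gives 0.45 mL/min and compound 3 gives 0.34 mL/min. Compound 3 shows the lowest of the three numbers, but its nearest neighbour, compound 2, sits within the scatter of it, and so does compound 1, the furthest of the three. Within the data shown here, on these numbers the three measured compounds are therefore not separated from one another in this assay, and no single-point step between measured compounds is available to guide a prediction.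

Compound 4 `O=S(=O)(c1ccc(F)cc1)c1cnc2ccc(Cl)cc2c1-c1ccc(Cl)cc1` has not yet been run in this assay. Its difference from compound 3 is hydrogen in place of fluoro on an aromatic carbon, with the place on an aromatic carbon of the fused two-ring system of compound 3, ortho to the chloro group.

Among the measured compounds shown here, no comparable step exists among the measured compounds, so the change is read against the spread of the three numbers alone. The expectation is for a step from compound 3 to compound 4 of a 1.3-fold higher number from compound 3 to compound 4 (0.12 log units; within the scatter), that is, no change beyond the scatter, with a slight lean toward a higher number. Compound 4 is accordingly estimated at 0.45 mL/min, with a range from 0.25 mL/min to 0.85 mL/min.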

Compound 4, intrinsic clearance in a liver preparation (reported as CLH), per the amount of preparation that the assay uses: 0.2 mL/min
Estimate against measurement, compound 4: 2.3-fold (0.35 log units) above; measured number outside the range, below it.
By their numbers in this assay, from the lowest: compounds 4, 3, 2 and 1 (each within the scatter of the next, the first and the last beyond it).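

Among these compounds, this is the first step that changes one place only: in this assay, hydrogen in place of fluoro on an aromatic carbon, ortho to a chloro group, para to a fused ring and meta to a fused ring, gives a 1.7-fold lower number from compound 3 to compound 4 (0.23 log units; within the scatter). The fluoro group can therefore leave this place on the core of compound 3 without a change beyond the scatter, so this read-out gives no sign that the fluoro group is needed there to keep the number low. Nothing measured here bears on why the step has this size or direction.

From the compounds shown here alone, this single step describes only two substituents at one place on one core, so the result of a methoxy group, a nitrile or an amine at the same carbon remains open. Going by these compounds, whether hydrogen in place of fluoro gives a step of similar size on the core of compound 1 or compound 2, where the surrounding groups differ, also remains open.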